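A few compounds are considered here, and "the series" means these few. Any claim that something is new, unique, unknown or untested is made for them only; others in the source may bear on it.

Three thiourea analogues sharing one core were tested in an ADME assay on Ava5 cells (Homo sapiens) for cytotoxicity; on this read-out higher numbers stand for lower toxicity in this test and lower numbers for higher toxicity in this test. Compound 1 `NC(=S)Nc1cccc(Oc2ccccc2)c1` carries a phenyl on the aromatic oxygen. In this assay compound 1 gives only a limit of the assay, > 50000 nM. Compound 2 `NC(=S)Nc1cccc(OCc2ccccc2)c1` carries a benzyl there instead. In this assay compound 2 likewise reaches only the limit, > 50000 nM. Compound 3 `NC(=S)Nc1cccc(OCCCc2ccccc2)c1` extends the linker further. In this assay compound 3 again gives a limit and no number, > 50000 nM. So compound 3 stands where the whole set stands: all three values sit at the same limit, as summarised by the limit of > 50000 nM in this assay, at which 3 of the 3 values shown sit, and no step between any two of them can be measured.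

Compound 4 `NC(=S)Nc1cccc(OCCCCc2ccccc2)c1` has not yet been measured. It differs from compound 3 by benzyl in place of phenyl on a saturated chain carbon, three bonds along the chain from an oxygen on an aromatic ring, that is, the chain grows by one carbon. Nothing in the measured set reaches a number, so the expected step from compound 3 to compound 4, a step that the limit leaves unreadable from compound 3 to compound 4, is none beyond the scatter. For compound 4 the estimated value in this assay is 60000 nM, with a range from 40000 nM to 100000 nM, most likely again reported only as the limit.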

Compound 4, half-maximal cytotoxic concentration: > 50000 nM
Compound 4: only a limit was reported; the forecaster's own chance of this, stated with the estimate: 85%; the middle value is on the limit's open side.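

For the compounds shown here, compound 4 also gives only a limit, so no step between compound 3 and compound 4 can be read: the limit of > 50000 nM in this assay, at which 4 of the 4 values shown sit. The compounds shown leave open how far any of them lies beyond that limit, and whether chain length changes the read-out at all.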